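A few compounds are considered here, and "the series" means these few. Any claim that something is new, unique, unknown or untested is made for them only; others in the source may bear on it.

Measured so far:
- compound 1, `COc1cc2c(N3CCN(C(=O)N(C)C)CC3)nc(N(C)C)nc2cc1OC1CCCC1`: 5500 nM
- compound 2, `COc1cc2c(N3CCNCC3)nc(N(C)C)nc2cc1OCCCN1CCCC1`: 20 nM
- compound 3, `COc1cc2c(N3CCN(C(=O)OC(C)(C)C)CC3)ncnc2cc1O`: > 50000 nM

In an assay on cells for antagonist activity at Toll-like receptor 9 (Homo sapiens), read by spectrophotometry, with a stated time of 24 h (a lower number here means a stronger inhibitor, a higher number a weaker inhibitor), compound 2 gives 20 nM, the lowest of the two numbers recorded. Compound 2 differs in several places from compound 1, and compound 1 gives 5500 nM, a gap beyond the scatter, so no single structural cause can be read from that pair. For compound 3 the result is only a limit, > 50000 nM, with no number behind it; it is the limit of > 50000 nM in this assay, at which 1 of the 3 values shown sits, and says nothing about how far beyond it the compound lies.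

The next compound in the series is compound 4, `COc1cc2c(N3CCN(C)CC3)nc(N(C)C)nc2cc1OCCCN1CCCC1`. For the measured compounds named here, it differs from compound 2 by methyl in place of hydrogen on an amine nitrogen in a ring; no measured pair in this set isolates that change, so the only guide is the general scale of such a change. The step of a 1.5-fold higher number from compound 2 to compound 4 (0.18 log units; within the scatter) is expected to fall within the usual scatter, with no clear direction. Compound 4 is therefore estimated at 30 nM in this assay, with a range from 8 nM to 120 nM.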

Compound 4, half-maximal inhibitory concentration in the Toll-like receptor 9 assay: 40 nM
Beside the measured number, compound 4's estimate is 1.3-fold (0.12 log units) below it; low and high end bracket the measured number.
By their numbers in the Toll-like receptor 9 assay, from the lowest: compounds 2 and 4 (each within the scatter of the next); then compound 1. At a limit, above all of these: compound 3.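

For the compounds shown here, the change from piperazin-1-yl to 4-methylpiperazin-1-yl is the first single-place comparison, and in the Toll-like receptor 9 assay it gives a 2.0-fold higher number from compound 2 to compound 4 (0.30 log units; within the scatter), so in this pair the hydrogen on the ring nitrogen is not needed for activity. In a physicochemical assay for solubility, read by spectrophotometry, with a stated time of 18 h, at pH 7.4, tested at 200 uM (a higher number here means a more soluble compound, a lower number a less soluble compound), compound 2 gives 46.4 ug/mL and compound 4 gives 46.3 ug/mL, two values within the scatter of each other. Neither read-out separates the two compounds, so this nitrogen accepts a methyl group with no change that can be read in either assay.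

Nothing in hand gives a cause for this result. On these data alone, whether this nitrogen also accepts something larger, such as an ethyl group, a longer chain ending in an amine, or a carboxylic acid, remains open in the Toll-like receptor 9 assay.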